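A few compounds are considered here, and "the series" means these few. Any claim that something is new, unique, unknown or untested is made for them only; others in the source may bear on it.

Measured in a functional assay on NCI-H1581 cells (Homo sapiens) for inhibition, read by MTT assay, with a stated time of 48 h, tested at 10 uM; a higher number here means more inhibition at the concentration tested (going by the name of the read-out), a lower number less inhibition:
compound 1, `COc1cc(Br)ccc1Nc1cc(NC(=O)Nc2c(Cl)cccc2Cl)ncn1`, 47.3%
compound 2, `COc1ccc(Br)cc1Nc1cc(NC(=O)Nc2c(Cl)cccc2Cl)ncn1`, 53.3%
compound 3, `COc1cc(NC(=O)Nc2cc(Nc3ccc(Br)cc3OC)ncn2)cc(OC)c1`, 20.1%

Compound 4, `COc1cc(NC(=O)Nc2cc(Nc3cc(Br)ccc3OC)ncn2)cc(OC)c1`, has not yet been measured in this assay. The change from compound 3 to compound 4 is 5-bromo-2-methoxyphenyl in place of 4-bromo-2-methoxyphenyl on a nitrogen on an aromatic ring. The same change has been made once before, from compound 1 to compound 2, as 5-bromo-2-methoxyphenyl in place of 4-bromo-2-methoxyphenyl on a nitrogen on an aromatic ring, and there it gave a number 6 percentage points higher from compound 1 to compound 2 (within the scatter). The place of the change reads the same in both pairs, so this counts as the same change. The two cores differ in one respect, (3,5-dimethoxyphenyl in place of 2,6-dichlorophenyl on an amide-type nitrogen), which gave a number 27.2 percentage points lower from compound 1 to compound 3 (beyond the scatter). Compound 3 stands lowest of the three measured compounds, both steps to it lying beyond the scatter. For compound 4 the expected step of a number 5.9 percentage points higher from compound 3 to compound 4 (within the scatter) is set beside the earlier step because the same change on compound 1 gave a number 6 percentage points higher from compound 1 to compound 2 (within the scatter), and that single instance lay within the scatter. Compound 4 is therefore estimated at 26%, expected between 12% and 40%.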

Compound 4, a percentage reported as inhibition, at one concentration (the size of the read-out at that concentration, not a potency): 23.1%
Compound 4: middle estimate off by 2.9 percentage points, on the high side, and the stated range covers the measured number.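

In this assay the move to 5-bromo-2-methoxyphenyl on the core of compound 3 gives a number 3 percentage points higher from compound 3 to compound 4 (within the scatter) and matches its earlier instance: the same change on two cores in this assay, a number 6 percentage points higher (within the scatter) from compound 1 to compound 2 and a number 3 percentage points higher (within the scatter) from compound 3 to compound 4, 3 percentage points apart, within the scatter of two such steps. Replacing 2,6-dichlorophenyl with 3,5-dimethoxyphenyl on the amide-type nitrogen gives a number 30.2 percentage points lower from compound 2 to compound 4 (beyond the scatter) and also carries over: the same change on two cores in this assay, a number 27.2 percentage points lower (beyond the scatter) from compound 1 to compound 3 and a number 30.2 percentage points lower (beyond the scatter) from compound 2 to compound 4, 3 percentage points apart, within the scatter of two such steps. Across these four compounds the two changes behave consistently, but with both bromine steps within the scatter, this does not show that the bromine move alters the read-out, and two cores establish no general rule.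

As far as these compounds go, it remains open whether this consistency holds with a cyclohexyl group or a longer chain on the amide-type nitrogen. Also open, from the compounds shown here alone, is what an amine or a nitrile would do in place of the bromine.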